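This account rests on a few compounds, and the source may have more. Where it says the series, first, only, none or still open, it means among the compounds named here.

In a functional assay on MCF7 cells (Homo sapiens) for antiproliferative activity, read by MTT assay, with a stated time of 72 h (a higher number here means a weaker inhibitor, a lower number a stronger inhibitor), compound 1 `CCCCC(=O)c1cc(C(CC)(CC)c2ccc(C#CC(O)(CC)CC)c(C)c2)cn1CC` reaches only a limit, > 50000 nM. Compound 2 `CCn1cc(C(CC)(CC)c2ccc(C#CC(O)(CC)CC)c(C)c2)cc1C(=O)NCC(=O)O` gives 17500 nM and compound 3 `CCn1cc(C(CC)(CC)c2ccc(C#CC(O)(CC)CC)c(C)c2)cc1C(=O)N[C@H](C(=O)O)C(C)C` gives 12600 nM, two values within the scatter of each other. Compound 4 `CCn1cc(C(CC)(CC)c2ccc(C#CC(O)(CC)CC)c(C)c2)cc1C(=O)N[C@@H](C(=O)O)C(C)C` differs from compound 3 in this way: the two compounds have the same atoms and bonds and differ only in configuration as drawn: 1 of 1 stereo elements differ; a stereocentre at a saturated chain carbon is drawn S in compound 3 and R in compound 4. For the measured compounds named here, no measured step changes configuration alone. The closest is a 1.4-fold lower number from compound 2 to compound 3 (0.14 log units; within the scatter), which places isopropyl in place of hydrogen on a saturated chain carbon. The step of an at least 3.9-fold lower number from compound 1 to compound 3 (0.59 log units; beyond the scatter) installs the (1-carboxy-2-methylpropyl)amino group, which compound 4 keeps. Only a change within the scatter is therefore expected in this assay, and the expected step is a 1.1-fold higher number from compound 3 to compound 4 (0.05 log units; within the scatter). For compound 4 the estimate is 14000 nM, with an expected range of 6000 nM to 32000 nM.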

Compound 4, half-maximal inhibitory concentration: 18000 nM
Beside the measured number, compound 4's estimate is 1.3-fold (0.11 log units) below it; the range from low to high includes it.
By their numbers in this assay, from the lowest: compounds 3, 2 and 4 (each within the scatter of the next). At a limit, above all of these: compound 1.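

In this assay, the configuration at the saturated chain carbon makes no difference beyond the scatter, the step being a 1.4-fold higher number from compound 3 to compound 4 (0.15 log units; within the scatter), and this comparison isolates that stereocentre: the fact that compounds 3 and 4 differ only in the configuration as drawn With the R configuration, isopropyl in place of hydrogen also stays within the scatter, at a 1.0-fold higher number from compound 2 to compound 4 (0.01 log units; within the scatter). The (1-carboxy-2-methylpropyl)amino group in place of butyl still gives an at least 2.7-fold lower number from compound 1 to compound 4 (0.44 log units; beyond the scatter), a step measured from a limit: the limit of > 50000 nM in this assay, at which 1 of the 4 values shown sits. The compounds shown leave open whether a methyl ester in place of the carboxylic acid, or benzyl in place of isopropyl, would keep the number at this level.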